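Thiazole substituent swap in a DU-145 growth assay

The source may hold more compounds than are shown below. What is called first, only, known or untested is meant among the compounds shown, and "the series" means these compounds.

The two measured compounds share a tosyl-linked thiosemicarbazide or hydrazide motif. Compound 1 `Cc1ccc(S(=O)(=O)NNC(N)=S)cc1` is a thiosemicarbazide that in a functional assay on DU-145 cells (Homo sapiens) for inhibition, read by XTT assay, with a stated time of 72 h (a lower number here means a stronger inhibitor, a higher number a weaker inhibitor), gives 8980 nM. Compound 2 `CC(=O)N(c1nc(C)cs1)N(C(C)=O)S(=O)(=O)c1ccc(C)cc1` carries a diacetylated hydrazine bearing a methyl-substituted thiazole, and in this assay compound 2 gives 7630 nM. On these two numbers compound 2 stands level with compound 1, the gap between them lying within the scatter, so neither can be called the stronger.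

Compound 3 `CC(=O)N(c1nc(-c2ccccc2)cs1)N(C(C)=O)S(=O)(=O)c1ccc(C)cc1` is the next step: phenyl in place of methyl on an aromatic carbon. Going by the values given here, no measured pair shows what such a change does here, so the direction is open. The author expects a step of a 1.5-fold lower number from compound 2 to compound 3 (0.18 log units; within the scatter), modest and probably toward slightly stronger inhibition. The estimate for compound 3 in this assay is 5000 nM, with a range from 1500 nM to 20000 nM.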

Compound 3, half-maximal inhibitory concentration: > 58200 nM
Compound 3: only a limit was reported; the forecaster's own chance of this, stated with the estimate: 10%; middle value at least 11-fold (1.06 log units) from the limit.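

Phenyl in place of methyl on this aromatic carbon, next to the ring nitrogen, brings an at least 7.6-fold higher number from compound 2 to compound 3 (0.88 log units; beyond the scatter), so the change weakens inhibition and the position proves sensitive to the group it carries. Going by these compounds alone, compound 1 and compound 2, level with each other, gave no view of this, as no measured pair had tested a change at this carbon. The full size of the step remains unknown, as compound 3 is recorded only as a limit and not as a number: the limit of > 58200 nM in this assay, at which 1 of the 3 values shown sits.

The compounds shown leave open whether the loss follows from the larger group as such or from its aromatic ring, a question that an ethyl or a cyclohexyl group on the same carbon would address. They also leave open whether an amine or a carboxylic acid on the phenyl ring would restore inhibition.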